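A few compounds are considered here, and "the series" means these few. Any claim that something is new, unique, unknown or untested is made for them only; others in the source may bear on it.

Compound 1 (`Cc1ccc(-c2cc(/C=N/c3ccccc3)on2)cc1`): in a functional assay on A549 cells (Homo sapiens) for inhibition, read by MTT assay, with a stated time of 24 h (a higher number here means a weaker inhibitor, a lower number a stronger inhibitor), compound 1 gives 32000 nM.
Compound 2 (`CCc1cc2ccccc2nc1-c1cc(-c2ccccc2)no1`): in this assay compound 2 gives > 100000 nM, which is a limit of the assay and not a number.

Of the two measured compounds, compound 2 stands at the limit of > 100000 nM in this assay, at which 1 of the 2 values shown sits. Compound 3 (`CCCCCc1cc2ccccc2nc1-c1cc(-c2ccccc2)no1`) differs from compound 2 by propyl in place of hydrogen on a saturated chain carbon, two bonds along the chain from an aromatic carbon. For the measured compounds named here, no step between two measured compounds is available to guide the size of this change; the only comparison it has is the limit of compound 2. The step is expected to be small, probably none beyond the scatter, so that compound 3 most likely remains at the limit; the estimate for compound 3 is 100000 nM, with a range from 30000 nM to 300000 nM. That estimate means an expected step of a number no higher from compound 2 to compound 3 (the limit leaves the size open).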

Compound 3, half-maximal inhibitory concentration: 92300 nM
The estimate for compound 3 lay 1.1-fold (0.03 log units) above the measured number; low and high end bracket the measured number.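

For the compounds shown here, with propyl on this saturated chain carbon, the shared core of compound 2 yields a measured number for the first time: compound 3 gives 92300 nM. In this assay, the change amounts to an at least 1.0-fold lower number from compound 2 to compound 3 (0.03 log units; that floor lies within the scatter), so it shows no step beyond the scatter. The value of compound 2 is a limit of the assay and not a number: the limit of > 100000 nM in this assay, at which 1 of the 3 values shown sits.

From the compounds shown here alone, the true size of this step remains open. So does whether a longer chain, or an amine or a carboxylic acid at the end of the chain, would shift the number beyond the scatter.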